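Adding a chloro to the phenyl of compound 2

The compounds below may be only part of what the source reports. "The series", "measured", "known", "first", "only" and "open" are said of these compounds alone.

Measured so far in a functional assay on COLO 205 cells (Homo sapiens) for antiproliferative activity, read by MTT assay, with a stated time of 68 h; a lower number here means a stronger inhibitor, a higher number a weaker inhibitor:
compound 1 `COc1n[nH]c2ncc(C#Cc3c(F)ccc(NS(=O)(=O)c4cccnc4)c3F)cc12`: 89 nM
compound 2 `O=S(=O)(Nc1ccc(F)c(C#Cc2cnc3[nH]nc(-c4ccccc4)c3c2)c1F)c1cccnc1`: 200 nM

Compound 2 stands at the higher of the two numbers. Among the measured compounds shown here, its nearest neighbour is compound 1, and the one step between them, a 2.2-fold higher number from compound 1 to compound 2 (0.35 log units; beyond the scatter), comes from a phenyl in place of a methoxy on an aromatic carbon of the shared core.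

Compound 3 `O=S(=O)(Nc1ccc(F)c(C#Cc2cnc3[nH]nc(-c4ccccc4Cl)c3c2)c1F)c1cccnc1` keeps that phenyl and adds one atom to it: chloro in place of hydrogen on an aromatic carbon. The change sits on the phenyl itself, ortho to a large group, and the same difference read one bond further out is phenyl to 2-chlorophenyl.

For the measured compounds named here, no measured pair shows this change. Going by the values given here, the only step on record, a 2.2-fold higher number from compound 1 to compound 2 (0.35 log units; beyond the scatter), concerns the group on the core rather than a substituent on that group, so it bears on compound 3 only loosely. With nothing to point in either direction, compound 3 is expected to give a number close to that of compound 2, no change at the digits printed from compound 2 to compound 3 (within the scatter), within the scatter. The estimate for compound 3 is therefore 200 nM, with a range from 80 nM to 500 nM.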

Compound 3, half-maximal inhibitory concentration: 3600 nM
The estimate for compound 3 lay 18-fold (1.26 log units) below the measured number, and the stated range ends below it.
By their numbers in this assay, from the lowest: compound 1; then compound 2; then compound 3.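

In this assay, the phenyl turns out to be a sensitive place: adding a single chloro ortho to a large group gives an 18-fold higher number from compound 2 to compound 3 (1.26 log units; beyond the scatter), a large step, whereas replacing the whole methoxy with phenyl gave only the modest 2.2-fold higher number from compound 1 to compound 2 (0.35 log units; beyond the scatter). Read against the methoxy of the shared core, the 2-chlorophenyl gives a 40-fold higher number from compound 1 to compound 3 (1.61 log units; beyond the scatter), so the group on the core can be changed at a modest cost as phenyl but at a large one as 2-chlorophenyl, and most of that loss comes with the one heavy atom added to the phenyl. Nothing measured on these compounds accounts for the size of this step.

The compounds shown leave open whether the loss belongs to chloro in particular or would also follow from a fluoro or a methyl in the same place, and whether a chloro elsewhere on the phenyl would bring the same large step. They also leave open whether an amine or a hydroxyl on that carbon would keep the number close to that of compound 2 or raise it as the chloro does.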